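The source may report more compounds than this note shows. Statements on the series, on what has been measured and on what is new or still open speak of the compounds shown alone.

Measured in a functional assay on HepG2 cells (Homo sapiens) for cytotoxicity; on this read-out lower numbers stand for higher toxicity in this test and higher numbers for lower toxicity in this test:
- Compound 1 `Nc1ncnc2c1ncn2[C@H]1C=C[C@@H](CO)C1`: > 200000 nM
- Compound 2 `Nc1ncnc2c1ncn2[C@@H]1C=C[C@H](CO)C1`: > 200000 nM
- Compound 3 `Nc1ncnc2c1ncn2[C@@H]1CC[C@H](CO)C1`: > 200000 nM

Each of these three values is a limit of the assay and not an exact number.

Compound 3 reads > 200000 nM, which is a limit. It therefore has no exact position among the three compounds, and the data show (the limit of > 200000 nM in this assay, at which 3 of the 3 values shown sit).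

Compound 4 `Nc1ncnc2c1ncn2[C@H]1CC[C@@H](CO)C1` has the same atoms and bonds as compound 3 and is its mirror image: the two compounds have the same atoms and bonds and differ only in configuration as drawn: 2 of 2 stereo elements differ (all stereocentres are inverted: mirror images); a stereocentre at a saturated ring carbon is drawn R in compound 3 and S in compound 4; a stereocentre at a saturated ring carbon is drawn S in compound 3 and R in compound 4. All stereocentres are inverted, and nothing leaves or enters.

Within the data shown here, the only measured step of this kind is a step that the two limits leave unreadable from compound 1 to compound 2. Its size cannot be read, so it offers no number to carry over. It still bears on the present change through (the fact that compounds 1 and 2 differ only in the configuration as drawn), and neither mirror image in that pair gives a value beyond the limit.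

With only this to go on, the expected step is no larger than the usual scatter, with no expected direction: a step that the limit leaves unreadable from compound 3 to compound 4. In this assay, the estimate for compound 4 is 250000 nM, with an expected range from 120000 nM to 500000 nM, and a report of only a limit is likely.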

Compound 4, half-maximal cytotoxic concentration: > 200000 nM
Compound 4: no number, only a limit; the forecaster's own chance of this, stated with the estimate: 90%; the middle value does not contradict the limit.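

In this assay compound 4 gives > 200000 nM, which is a limit of the assay and not an exact number. Compound 3 also has only a limit, and the step between these two mirror images cannot be read. The compounds shown leave open whether their exact values differ at all, including between mirror images.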